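The compounds below may be only part of what the source reports. "The series", "measured", "known", "first", "only" and "open" are said of these compounds alone.

Working notes on the series.

Two compounds have numbers in an ADME assay on microsomes from liver (Homo sapiens) for metabolic stability, read by LC-MS, using NADPH, tested at 5 uM; on this read-out higher numbers stand for a longer-lived compound and lower numbers for a shorter-lived compound. Compound 1 `Cc1cc(S(=O)(=O)/N=C(\N)n2nccc2-c2ccccc2)c(SCc2ccc(Cl)cc2)cc1Cl` gives 0.34 h in this assay, the highest of the two numbers shown. Compound 2 `Cc1cc(-c2ccccc2)n(/C(N)=N/S(=O)(=O)c2cc(C)c(Cl)cc2SCc2ccccc2C)n1` gives 0.154 h in this assay, a lower number than compound 1, and that gap lies beyond the usual scatter of repeated measurements. Within the data shown here, no step between the two is counted here, since their structures differ in more than one place, so nothing more is read from the pair than the two numbers themselves.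

Compound 3 `Cc1cccc(CSc2cc(Cl)c(C)cc2S(=O)(=O)/N=C(\N)n2nccc2-c2ccccc2)c1` has not yet been measured in this assay. Against compound 1 the change is 3-methylphenyl in place of 4-chlorophenyl on a saturated chain carbon bound to a sulfur. Among the measured compounds shown here, with only two measured compounds, and none of them differing from compound 3 in a single place, there is no step in this assay that maps onto this change.

The working expectation is a step from compound 1 to compound 3 of a 1.5-fold lower number from compound 1 to compound 3 (0.19 log units; within the scatter) in this assay, modest and downward, but a step no larger than the scatter would not be surprising. On that basis compound 3 is estimated at 0.22 h in this assay, with a range from 0.1 h to 0.45 h.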

Compound 3, half-life: 0.232 h
Beside the measured number, compound 3's estimate is 1.1-fold (0.02 log units) below it; measured number inside the range.
By their numbers in this assay, from the lowest: compounds 2, 3 and 1 (each within the scatter of the next, the first and the last beyond it).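

Among these compounds, this is the first step that can be read at a single place: on a saturated chain carbon bound to a sulfur, 3-methylphenyl in place of 4-chlorophenyl gives a 1.5-fold lower number from compound 1 to compound 3 (0.17 log units; within the scatter) in this assay, the only step available at this position. That step lies within the usual scatter of repeated measurements, so this read-out does not separate compound 1 from compound 3, and this particular exchange of one substituted phenyl for another leaves the half-life indistinguishable from that of compound 1. Nothing in these notes bears on why the two compounds read alike.

The step exchanges the chlorine for a methyl and alters the ring position of the substituent in one move, so the compounds shown do not tell these two changes apart. From the compounds shown here alone, it also remains open whether the position tolerates groups of another kind on that chain carbon, such as a pyridine ring, a cyclohexyl group or a phenyl ring carrying a carboxylic acid or an amine.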